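A few compounds are considered here, and "the series" means these few. Any claim that something is new, unique, unknown or untested is made for them only; others in the source may bear on it.

Of the compounds shown here, two built on the shared core have been read so far in an ADME assay (liver) for metabolic stability, with Liver microsome (Rattus norvegicus) as the target, read by LC-MS, using microsomes, with a stated time of 30 min, tested at 4 uM; a lower number here means that less of the compound is left, a higher number that more of the compound is left. Compound 1 `COCCn1c(-c2ccccc2Cl)nc2c(N3CCN(C(C)=O)CC3)nc(C)nc21` gives 95%. Compound 2 `COc1cccc(-c2nc3c(N4CCN(C)CC4)nc(C)nc3n2C2CCOCC2)c1` gives 30%, the lower of the two numbers, and the gap to compound 1 lies beyond the scatter of repeated measurements.

Compound 3 `CCc1ccccc1-c1nc2c(N3CCN(C)CC3)nc(C)nc2n1C1CCOCC1` has not yet been measured. It departs from compound 2 in one place, carrying 2-ethylphenyl in place of 3-methoxyphenyl on an aromatic carbon. The rest of compound 2 stays as it is, including the oxan-4-yl group.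

Among the measured compounds shown here, the two measured compounds differ in more than one place, so no single-change step is available as a guide. The high reading of compound 1 at 95% therefore says little about this swap. The closest reference is compound 2 at 30%. The expected step is small and slightly upward, a number 5 percentage points higher from compound 2 to compound 3 (within the scatter), which would stay within the usual scatter. For compound 3 the estimated value is 35%, with an expected range from 15% to 60%.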

Compound 3, percent of the compound remaining: 51%
Compound 3: the middle estimate sits 16 percentage points below what was measured; measured number inside the range.
By their numbers in this assay, from the lowest: compound 2; then compound 3; then compound 1.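

In this assay, the aromatic carbon next to the ring atom that bears the oxan-4-yl group proves sensitive to the choice of aryl group, with 2-ethylphenyl in place of 3-methoxyphenyl giving a number 21 percentage points higher from compound 2 to compound 3 (beyond the scatter). This is the first single-change step among the compounds shown, and it isolates the aryl group in a way that the comparison of compound 1 with compound 2 could not, as those two differ in more than one place. No measurement accompanies the step to say why the reading moves.

The swap alters two things at once, the group on the phenyl ring and its place there, so only compounds carrying 3-ethylphenyl or 2-methoxyphenyl could show which of the two accounts for the step. Also open, as far as these compounds go, is whether a longer chain such as 2-propylphenyl, or a nitrile or a carboxylic acid on the phenyl ring, would move the reading further, and whether the step holds when another group stands in place of oxan-4-yl.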